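From compound 2 to compound 3 in a cell assay

A few compounds are considered here, and "the series" means these few. Any claim that something is new, unique, unknown or untested is made for them only; others in the source may bear on it.

Compounds measured so far in a functional assay on HCT-116 cells (Homo sapiens) for antiproliferative activity, read by MTT assay, with a stated time of 48 h (a higher number here means a weaker inhibitor, a lower number a stronger inhibitor), are these:
Compound 1 `COc1ccc(N(C)c2ccnc(Cl)n2)cc1OCCCCCBr` gives > 10000 nM as a limit
Compound 2 `COc1ccc(N(C)c2ccnc(Cl)n2)cc1OCCC[Se]C#N` gives 3920 nM as a number

Among the measured compounds shown here, compound 2 holds the only actual number so far, since the result for compound 1 is a limit. Compound 3 `COc1ccc(N(C)c2ccnc(Cl)n2)cc1OCCCC[Se]C#N` carries a single change against compound 2, namely a group of 4 heavy atoms (2 carbon, 1 nitrogen, 1 selenium; no ring) in place of a group of 3 heavy atoms (1 carbon, 1 nitrogen, 1 selenium; no ring), on a saturated chain carbon, three bonds along the chain from an oxygen on an aromatic ring while the rest of the structure is shared. For the measured compounds named here, the one measured step that bears on this is an at least 2.5-fold lower number from compound 1 to compound 2 (0.40 log units; beyond the scatter) and it rests on a limit and on a different group leaving, so it sets no firm size for the new change. No step beyond the scatter is therefore expected in this assay here. The estimated step is a 1.3-fold lower number from compound 2 to compound 3 (0.12 log units; within the scatter) and it is expected to stay small. Compound 3 is expected at 3000 nM with a range from 1200 nM to 8000 nM as estimated here.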

Compound 3, half-maximal inhibitory concentration: > 10000 nM
Compound 3: only a limit was reported; the forecaster's own chance of this, stated with the estimate: 10%; middle value at least 3.3-fold (0.52 log units) from the limit.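

In this assay, the change on a saturated chain carbon, three bonds along the chain from an oxygen on an aromatic ring, proves not to be neutral: the group of 4 heavy atoms in place of the group of 3 heavy atoms gives an at least 2.5-fold higher number from compound 2 to compound 3 (0.40 log units; beyond the scatter). Compound 3 gives > 10000 nM, which is a limit, so this step has a minimum size but no exact one. Among the compounds shown, only compound 2 gives an actual number, the step from compound 1 to compound 3 cannot be read, and the values gather at one limit: the limit of > 10000 nM in this assay, at which 2 of the 3 values shown sit.

On these data alone, it remains open how a shorter chain than that of compound 2 would read in this assay. As far as these compounds go, it is also open whether a thiocyanate or an amine at the chain end would give a number or another limit.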